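Series notes: methyl to ethyl on the piperazine nitrogen

A few compounds are considered here, and "the series" means these few. Any claim that something is new, unique, unknown or untested is made for them only; others in the source may bear on it.

Measured so far:
compound 1, `CN1CCN(CCCN(C[C@H]2Cc3ccccc3CN2)[C@H]2CCCc3cccnc32)CC1`: 53%
compound 2, `c1cnc2c(c1)CCC[C@@H]2N(CCCN1CCNCC1)Cc1nc2ccccc2s1`: 45%
compound 3, `c1ccc2c(c1)CN[C@H](CN(CCCN1CCNCC1)[C@H]1CCCc3cccnc31)C2`: 88%

In an ADME assay on microsomes from liver (Mus musculus) for metabolic stability, read by LC-MS, with a stated time of 10 min, tested at 0.5 uM (a higher number here means that more of the compound is left, a lower number that less of the compound is left), compound 1 gives 53% and so holds the second highest of the three numbers. Compound 2 with 45% lies within the scatter of it, so the two cannot be ordered. Compound 3 with 88% lies beyond the scatter above compound 1. Among the compounds with values here, the single one-place step among the measured compounds, a number 43 percentage points higher from compound 2 to compound 3 (beyond the scatter), concerns the group on the saturated chain carbon bound to the amine nitrogen and does not touch the piperazine.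

Compound 4, `CCN1CCN(CCCN(C[C@H]2Cc3ccccc3CN2)[C@H]2CCCc3cccnc32)CC1`, differs from compound 1 by methyl in place of hydrogen on a saturated chain carbon bound to an amine nitrogen in a ring. Within the data shown here, no measured step bears on this change; compound 3 carries an unsubstituted piperazine and compound 1 a methylated one, but that pair differs elsewhere as well, so their two values show only that the methylated compound gave the lower number. With a single carbon added at the piperazine nitrogen, the expected step from compound 1 is a number 5 percentage points lower from compound 1 to compound 4 (within the scatter), that is, no change beyond the scatter, leaning slightly lower. Compound 4 is therefore estimated at 48%, in the range 30% to 66%.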

Compound 4, percent of the compound remaining: 19%
Compound 4: middle estimate off by 29 percentage points, on the high side; the measured number lies below the stated range.
By their numbers in this assay, from the lowest: compound 4; then compounds 2 and 1 (each within the scatter of the next); then compound 3.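

In this assay, the change from 4-methylpiperazin-1-yl to 4-ethylpiperazin-1-yl is a large one, a number 34 percentage points lower from compound 1 to compound 4 (beyond the scatter), so one added carbon at this position is enough to move the number well beyond the scatter. Within the data shown here, the only earlier one-place step, a number 43 percentage points higher from compound 2 to compound 3 (beyond the scatter), concerned the group on a saturated chain carbon bound to an amine nitrogen, so this is the first direct reading at the piperazine substituent, and it shows that the number depends on that substituent as well. Nothing at hand explains the size or the direction of this step.

Going by these compounds, whether the number keeps falling with a longer chain such as propyl on the piperazine nitrogen, or recovers with a branched group such as isopropyl or a 2-hydroxyethyl group, remains open, as does whether the ethyl step would be repeated with 1,3-benzothiazol-2-yl in place of 1,2,3,4-tetrahydroisoquinolin-3-yl. Compound 1 and compound 3 differ in more than one place, so the effect of methyl on the piperazine nitrogen alone cannot be read from this pair.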